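A few compounds are considered here, and "the series" means these few. Any claim that something is new, unique, unknown or untested is made for them only; others in the source may bear on it.

In an ADME assay on a cell-free system (plasma, Homo sapiens) for metabolic stability, read by LC-MS (a higher number here means that the compound lasts longer, a lower number that the compound disappears faster), compound 3 `CCCOC(=O)c1cccc(-c2cc(C(=O)Nc3ccncc3F)ccc2CN)c1` has a half-life of 0.317 h. This is the lower of the two numbers available, and compound 1 `NCc1ccc(C(=O)Nc2ccncc2)cc1-c1cccc(C(=O)OCc2ccccc2)c1` gives 1.07 h, a gap beyond the usual scatter. Compound 2 `NCc1ccc(C(=O)Nc2ccncc2F)cc1-c1cccc(C(=O)OCC2CCCO2)c1` gives < 0.0834 h, which is a limit of the assay and not a number. Going by the values given here, the one measured step, an at least 3.8-fold higher number from compound 2 to compound 3 (0.57 log units; beyond the scatter), is ethyl in place of oxolan-2-yl on a saturated chain carbon bound to an oxygen next to a carbonyl group. That step lies beyond the scatter, but it concerns the ester end of the molecule.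

The next compound, compound 4 `CCCOC(=O)c1cccc(-c2cc(C(=O)Nc3ccncc3)ccc2CN)c1`, is changed elsewhere, with hydrogen in place of fluoro on an aromatic carbon, so that 3-fluoropyridin-4-yl becomes pyridin-4-yl: hydrogen in place of fluoro on an aromatic carbon. Among the compounds with values here, no measured step isolates this change, so the step from compound 2 gives no direct guide to its size. Within the data shown here, the only hint comes from compound 1, which carries pyridin-4-yl and reaches 1.07 h, although its ester group differs as well. A small rise is therefore expected, and the estimated step, a 1.6-fold higher number from compound 3 to compound 4 (0.20 log units; within the scatter), is not expected to stand clearly beyond the scatter. For compound 4 the half-life is estimated at 0.5 h, with an expected range of 0.2 h to 1.2 h.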

Compound 4, half-life: 0.3 h
Beside the measured number, compound 4's estimate is 1.7-fold (0.22 log units) above it; the measured number falls inside the stated range.
By their numbers in this assay, from the lowest: compounds 4 and 3 (each within the scatter of the next); then compound 1. At a limit, below all of these: compound 2.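

In this assay, the fluoro on the aromatic carbon two atoms from the ring nitrogen proves to make no readable difference with this ester end in place: hydrogen in its place gives a 1.1-fold lower number from compound 3 to compound 4 (0.02 log units; within the scatter). With pyridin-4-yl now common to both compounds, the ester end alone still separates them, as ethyl in place of phenyl on a saturated chain carbon bound to an oxygen next to a carbonyl group gives a 3.6-fold lower number from compound 1 to compound 4 (0.55 log units; beyond the scatter). Going by these compounds alone, this adds a second step beyond the scatter at the ester end, while the one step at the fluoro position stays within it, and nothing measured here gives a cause for either step.

From the compounds shown here alone, the fluoro change has been read against one ester end only, so whether it stays as small with the phenyl or oxolan-2-yl groups at that end remains open. Also open, going by these compounds, is whether chloro or methoxy on the same aromatic carbon would read like fluoro and hydrogen, and whether an amide in place of the ester would change the half-life.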